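Ester variation on a shikonin-type core in HeLa cytotoxicity

A few compounds are considered here, and "the series" means these few. Any claim that something is new, unique, unknown or untested is made for them only; others in the source may bear on it.

Measured compounds:
compound 1, `CC(C)=CC[C@@H](OC(=O)c1ccco1)C1=CC(=O)c2c(O)ccc(O)c2C1=O`: 80300 nM
compound 2, `CCCC(O)CC(=O)O[C@H](CC=C(C)C)C1=CC(=O)c2c(O)ccc(O)c2C1=O`: 59300 nM
compound 3, `CC(=O)OCCO[C@H](CC=C(C)C)C1=CC(=O)c2c(O)ccc(O)c2C1=O`: 41500 nM

Three esters of a shared core were tested in a functional assay on HeLa cells (Homo sapiens) for cytotoxicity, read by MTT assay; on this read-out lower numbers stand for stronger inhibition and higher numbers for weaker inhibition. Compound 3 shows the lowest of the three numbers, yet its nearest neighbour compound 2 sits only a 1.4-fold lower number from compound 2 to compound 3 (0.16 log units; within the scatter) away and compound 1 only a 1.9-fold lower number from compound 1 to compound 3 (0.29 log units; within the scatter) away, so the three values cannot be told apart. Compound 4, `CC(C)=CC[C@@H](OC(=O)CC(C)(O)C(C)C)C1=CC(=O)c2c(O)ccc(O)c2C1=O`, has not been measured in this assay. It differs from compound 3 in one place: (2-hydroxy-2,3-dimethylbutyl)carbonyl in place of 2-acetoxyethyl on an oxygen on a saturated carbon. The change returns from the ether-type substituent of compound 3 to an acyl group carrying a hydroxyl, much as in compound 2, whose own step to compound 3 was a 1.4-fold lower number from compound 2 to compound 3 (0.16 log units; within the scatter), and in compound 1, whose step was a 1.9-fold lower number from compound 1 to compound 3 (0.29 log units; within the scatter). Both were within the scatter, so no step beyond the scatter is expected from compound 3 to compound 4 in this assay; the expected step is a 1.3-fold higher number from compound 3 to compound 4 (0.12 log units; within the scatter). Compound 4 is therefore estimated at 55000 nM, with a range from 25000 nM to 120000 nM.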

Compound 4, half-maximal inhibitory concentration: 27700 nM
Compound 4: the middle estimate sits 2.0-fold (0.30 log units) above what was measured; the range from low to high includes it.
By their numbers in this assay, from the lowest: compounds 4, 3, 2 and 1 (each within the scatter of the next, the first and the last beyond it).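

In this assay the step of a 1.5-fold lower number from compound 3 to compound 4 (0.18 log units; within the scatter) stays within the scatter, so on this oxygen on a saturated carbon the 2-acetoxyethyl group and the (2-hydroxy-2,3-dimethylbutyl)carbonyl group cannot be told apart. The new finding is that changes at this position now give modest steps beyond the scatter: with 1-hydroxy-1,2-dimethylpropyl in place of 1-hydroxybutyl the step is a 2.1-fold lower number from compound 2 to compound 4 (0.33 log units; beyond the scatter) and with 2-hydroxy-2,3-dimethylbutyl in place of furan-2-yl it is a 2.9-fold lower number from compound 1 to compound 4 (0.46 log units; beyond the scatter). Nothing available explains these steps. The compounds shown leave open how an acyl chain ending in an amine or a carboxylic acid would behave in this assay at this position. They also leave open whether a longer branched chain would carry the trend further.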